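Swapping Trifluoromethyl for Fluoro on a Shared Scaffold

The compounds below may be only part of what the source reports. "The series", "measured", "known", "first", "only" and "open" are said of these compounds alone.

Compound 1 `CCC(c1nc2ncc(Cl)cc2[nH]1)[C@H]1CC[C@@H](c2ccnc3ccc(C(F)(F)F)cc32)CC1` and compound 2 `CCC(Nc1nnc(-c2ccc(OC)cc2)o1)[C@H]1CC[C@@H](c2ccnc3ccc(C(F)(F)F)cc32)CC1` share a large part of their structure but carry different cores; the difference between the two cores is not broken down here. In an ADME assay on microsomes from liver (Mus musculus) for metabolic stability, with a stated time of 10 min, tested at 0.5 uM (a higher number here means that more of the compound is left, a lower number that less of the compound is left), compound 1 gives 57% and compound 2 gives 39%. Compound 3 `CCC(c1nc2ncc(Cl)cc2[nH]1)[C@H]1CC[C@@H](c2ccnc3ccc(F)cc32)CC1` arises from compound 1 by fluoro in place of trifluoromethyl on an aromatic carbon; in this assay compound 3 gives 7%, so the step is a number 50 percentage points lower from compound 1 to compound 3 (beyond the scatter). Compound 4 `CCC(Nc1nnc(-c2ccc(OC)cc2)o1)[C@H]1CC[C@@H](c2ccnc3ccc(F)cc32)CC1` arises from compound 2 by the same change at the same place, (fluoro in place of trifluoromethyl on an aromatic carbon). The step of a number 50 percentage points lower from compound 1 to compound 3 (beyond the scatter) leads to the expectation of a large drop for compound 4 as well. Since compound 2 gives 39%, the expected step of a number 31 percentage points lower from compound 2 to compound 4 (beyond the scatter) is smaller, as little of the compound can remain. Compound 4 is therefore estimated at 8%, between 2% and 25%.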

Compound 4, percent of the compound remaining: 31%
Beside the measured number, compound 4's estimate is 23 percentage points below it; the measured number lies above the stated range.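

Fluoro in place of trifluoromethyl does not carry over from one core to the other at the same size in this assay: the same change on two cores in this assay, a number 50 percentage points lower (beyond the scatter) from compound 1 to compound 3 and a number 8 percentage points lower (within the scatter) from compound 2 to compound 4, 42 percentage points apart, beyond the scatter of two such steps. On the core of compound 2, the step is a number 8 percentage points lower from compound 2 to compound 4 (within the scatter), so the change has no clear effect on that core, although it has a large one on the core of compound 1. These two pairs show that the outcome of this change depends on the core, but they do not show which part of the core matters, why it matters, or how a third core would respond.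

The compounds shown leave open how a nitrile or an amine at this place would fare on either core. They also leave open whether the difference between the two cores would persist with such groups.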